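Fused-core thiol series: removing the propyl group

A few compounds are considered here, and "the series" means these few. Any claim that something is new, unique, unknown or untested is made for them only; others in the source may bear on it.

Compound 1, `CCCc1nc(C)c2cnnc(SCC(=O)OCC)n12`: in a functional assay for inhibition, with Homo sapiens as the target (a lower number here means a stronger inhibitor, a higher number a weaker inhibitor), compound 1 gives > 48000 nM, which is a limit of the assay and not a number.
Compound 2, `CCCc1nc(C)c2cnnc(SC)n12`: in this assay compound 2 gives > 48000 nM, again a limit.
Compound 3, `CCCc1nnc(S)n2c(CCC)nc(C)c12`: in this assay compound 3 gives > 48000 nM, also a limit.

Compound 3 therefore stands where every measured member of the series stands, at the limit of > 48000 nM in this assay, at which 3 of the 3 values shown sit. For the measured compounds named here, no measured compound has a readable number. Going by the values given here, the only measured step between single-point neighbours, a step that the two limits leave unreadable from compound 1 to compound 2, stays unreadable because both of its ends are limits; it says nothing about size or direction.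

The next compound is compound 4, `CCCc1nc(C)c2cnnc(S)n12`. It differs from compound 3 by hydrogen in place of propyl on an aromatic carbon. Among the compounds with values here, no measured step touches this position, and the one measured step carries no information, so there is nothing from which a size or a direction could be read.

The expectation for compound 4 is accordingly set at the same limit as its three neighbours, with a number no higher from compound 3 to compound 4 (the limit leaves the size open) expected to show no step beyond the scatter. For compound 4 in this assay the estimate is 48000 nM, with a range from 20000 nM to 100000 nM, and the most likely outcome is that only a limit is reported.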

Compound 4, half-maximal inhibitory concentration: 10000 nM
Compound 4: the middle estimate sits 4.8-fold (0.68 log units) above what was measured, and the stated range ends above it.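

Hydrogen in place of propyl on the aromatic carbon gives an at least 4.8-fold lower number from compound 3 to compound 4 (0.68 log units; beyond the scatter) in this assay, the first sign in the series that this position can shift the read-out. The sulfur substituent matters as well: hydrogen in place of methyl gives an at least 4.8-fold lower number from compound 2 to compound 4 (0.68 log units; beyond the scatter), and hydrogen in place of (ethoxycarbonyl)methyl gives an at least 4.8-fold lower number from compound 1 to compound 4 (0.68 log units; beyond the scatter). Among these compounds only compound 4 carries hydrogen at both places, whereas compound 3 keeps the propyl group, compound 1 and compound 2 keep a group on sulfur, and all three remain at a limit: the limit of > 48000 nM in this assay, at which 3 of the 4 values shown sit.

On these data alone, each new step has a limit at one end, so its full size stays open, and the step between compound 1 and compound 2 cannot be read. Also open, as far as these compounds go, is whether a methyl or an ethyl group on that aromatic carbon, or an amine in place of the sulfanyl group, would keep a readable number in this assay.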